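Cytotoxicity notes: from compound 2 to compound 3

The source may hold more compounds than are shown below. What is called first, only, known or untested is meant among the compounds shown, and "the series" means these compounds.

Measured compounds:
- compound 1, `O=C(Nc1ncc(Cc2ccc(Cl)cc2)s1)c1ccc(F)cc1F`: "not toxic" (no number reported)
- compound 2, `CC(C)(C)OC(=O)Nc1ncc(C(Oc2ccc(F)c(Cl)c2)c2ccc(Cl)cc2)s1`: > 50000 nM

In an ADME assay on HepG2 2.2.15 cells (Homo sapiens) for cytotoxicity (on this read-out higher numbers stand for lower toxicity in this test and lower numbers for higher toxicity in this test), compound 1 is recorded as "not toxic" (no number reported) without a number. Compound 2 gives only a limit of the assay, > 50000 nM. Compound 2 therefore stands at the upper edge of what the measurement reports, as noted in the limit of > 50000 nM in this assay, at which 1 of the 2 values shown sits, and neither of the two entries offers a single number against which a step could be measured.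

Compound 3, `Cc1cc(Br)cc(OC(c2ccc(Cl)cc2)c2cnc(NC(=O)OC(C)(C)C)s2)c1`, is not yet measured. It differs from compound 2 in one place: 3-bromo-5-methylphenyl in place of 3-chloro-4-fluorophenyl on an oxygen on a saturated carbon. With no measured step in this assay between any two compounds shown, no step beyond the usual scatter is expected in either direction here, and the most likely outcome is again a reading at the limit.

The estimated step from compound 2 to compound 3 is a number no higher from compound 2 to compound 3 (the limit leaves the size open). Compound 3 is thus expected at 50000 nM, within 20000 nM to 120000 nM.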

Compound 3, half-maximal cytotoxic concentration: > 50000 nM
Compound 3: a limit, no number; the forecaster's own chance of this, stated with the estimate: 75%; the middle value lies on the limit itself.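

In this assay compound 3 gives > 50000 nM as a limit of the assay and not a number. Going by these compounds alone, compound 2 also reads only as a limit, so no step between compound 2 and compound 3 can be read: the limit of > 50000 nM in this assay, at which 2 of the 3 values shown sit.

The compounds shown leave open whether 3-bromo-5-methylphenyl in place of 3-chloro-4-fluorophenyl changes the half-maximal cytotoxic concentration at all.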